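Removing the Cyclohexyl Group from Compound 2

A few compounds are considered here, and "the series" means these few. Any claim that something is new, unique, unknown or untested is made for them only; others in the source may bear on it.

In a physicochemical assay for metabolic stability, in simulated intestinal fluid, with a stated time of 15 min, tested at 4 uM (on this read-out higher numbers stand for a more stable compound and lower numbers for a less stable compound), compound 1 (`CC[C@H](NC(=O)[C@H](COC)NC(=O)c1cc(C)on1)C(=O)N[C@@H](CC(C)C)C(=O)[C@@]1(C)CO1`) gives 100% and compound 3 (`COC[C@H](NC(=O)c1cc(C)on1)C(=O)N[C@H](C(=O)N[C@@H](CC(C)C)C(=O)[C@@]1(C)CO1)C(C)C`) gives 95%. Compound 2 (`COC[C@H](NC(=O)c1cc(C)on1)C(=O)N[C@@H](CC1CCCCC1)C(=O)N[C@@H](CC(C)C)C(=O)[C@@]1(C)CO1`) stands lowest of the three at 75%. Compound 4 (`COC[C@H](NC(=O)c1cc(C)on1)C(=O)N[C@@H](C)C(=O)N[C@@H](CC(C)C)C(=O)[C@@]1(C)CO1`), not yet measured, differs from compound 2 as follows: hydrogen in place of cyclohexyl on a saturated chain carbon, two bonds along the chain from an amide-type nitrogen and a carbonyl carbon. In short, cyclohexylmethyl becomes methyl. Within the data shown here, two measured steps bear on this change, both beyond the scatter. One is a number 25 percentage points lower from compound 1 to compound 2 (beyond the scatter), where cyclohexyl replaces methyl at the same place. The other is a number 20 percentage points higher from compound 2 to compound 3 (beyond the scatter), where isopropyl replaces cyclohexylmethyl. A step of similar size is therefore expected: a number 20 percentage points higher from compound 2 to compound 4 (beyond the scatter). The estimated value for compound 4 is 95%, with an expected range from 82% to 100%.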

Compound 4, percent of the compound remaining: 100%
Beside the measured number, compound 4's estimate is 5 percentage points below it; measured number inside the range.
By their numbers in this assay, from the lowest: compound 2; then compounds 3, 1 and 4 (each within the scatter of the next).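

Cutting the chain back to methyl gives a number 25 percentage points higher from compound 2 to compound 4 (beyond the scatter) in this assay, while the other two steps, a number 5 percentage points higher from compound 3 to compound 4 (within the scatter) and no change at the digits printed from compound 1 to compound 4 (within the scatter), show no real difference. Among these four compounds, then, only the cyclohexylmethyl of compound 2 stands apart, and methyl reads alike with the smaller chains of compound 1 and compound 3. Nothing measured here explains this difference.

The compounds shown leave open where along a longer straight chain the number would begin to fall. They also leave open how an amine or a carboxylic acid at this place would read.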